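The source may hold more compounds than are shown below. What is called first, only, known or untested is meant among the compounds shown, and "the series" means these compounds.

Compound 1 `N=C(NO)N/N=C/c1ccc(O)cc1` is a small hydroxy-substituted member of a series examined in an ADME assay on HeLa cells (Homo sapiens) for cytotoxicity; a lower number here means that less compound is tolerated, a higher number that more compound is tolerated. In this assay compound 1 gives > 100000 nM, which is a limit of the assay rather than a number. Compound 2 `N/C(=N\O)N/N=C/c1ccccc1O` belongs to the same series. In this assay compound 2 also reaches only a limit, > 100000 nM. Both results therefore sit at the limit of > 100000 nM in this assay, at which 2 of the 2 values shown sit. Compound 3 `COc1ccc(/C=N/NC(=N)NO)cc1` differs from compound 1 by methyl in place of hydrogen on an oxygen on an aromatic ring, which read one bond further out is hydroxy to methoxy. With both known compounds at the limit, no step beyond the scatter is expected in this assay. Compound 3 is estimated at 150000 nM, between 60000 nM and 400000 nM, an expected step that the limit leaves unreadable from compound 1 to compound 3.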

Compound 3, half-maximal cytotoxic concentration: > 100000 nM
Compound 3: only a limit was reported (the forecaster's own chance of this, stated with the estimate: 85%); the middle value does not contradict the limit.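

In this assay compound 1 and compound 3 both stop at a limit, so no step can be read for hydroxy to methoxy. The compounds shown leave open at what concentration any of them turns cytotoxic.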